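The source may report more compounds than this note shows. Statements on the series, on what has been measured and on what is new or still open speak of the compounds shown alone.

The compounds here share one core and differ in the groups attached to it, and all are tested in a functional assay on U2OS cells (Homo sapiens) for cytotoxicity, read by MTT assay, with a stated time of 48 h; on this read-out lower numbers stand for stronger inhibition and higher numbers for weaker inhibition. Compound 1 `Fc1cccc(-c2nc(Nc3ccccc3)c3ccccc3n2)c1` gives only a limit of the assay, > 50000 nM, and not a number. Compound 2 `Fc1ccc2nc(-c3ccccc3)nc(Nc3ccccc3)c2c1` also gives only a limit, > 50000 nM. Among the compounds with values here, compound 3 `COc1ccc(Nc2nc(-c3cccc(F)c3)nc3ccc(F)cc23)cc1`, which carries a (4-methoxyphenyl)amino group, gives 32300 nM, the only true number so far.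

Compound 4 `Fc1ccc(Nc2nc(-c3cccc(F)c3)nc3ccc(F)cc23)cc1` has fluoro in place of methoxy on an aromatic carbon, para to a large group: fluoro in place of methoxy on an aromatic carbon. Within the data shown here, no measured pair shows what this swap does, so the expectation rests on very little. With compound 3 at 32300 nM, no change beyond the usual scatter is expected in this assay, and any drift would most likely be toward weaker inhibition. The closest guide is the limit of > 50000 nM in this assay, at which 2 of the 3 values shown sit, so compound 4 may also return only a limit. The expected change is a 1.2-fold higher number from compound 3 to compound 4 (0.07 log units; within the scatter). The estimated value for compound 4 is 38000 nM, with an expected range of 15000 nM to 50000 nM.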

Compound 4, half-maximal inhibitory concentration: > 50000 nM
Compound 4 was reported as a limit (the forecaster's own chance of this, stated with the estimate: 45%); at least 1.3-fold (0.11 log units) between middle value and limit.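

In this assay compound 4 gives > 50000 nM, which is a limit of the assay and not a number. Fluoro in place of methoxy, on an aromatic carbon para to a large group, now has its first measured step, an at least 1.5-fold higher number from compound 3 to compound 4 (0.18 log units; that floor lies within the scatter), but this is only a floor, so the true size of the change remains unknown. The methoxy compound, compound 3, still holds the only true number, while compound 4 joins the compounds at the limit: the limit of > 50000 nM in this assay, at which 3 of the 4 values shown sit.

As far as these compounds go, whether any other group in this place, such as an amine, a hydroxyl or a longer ethoxy group, would give a true number remains open. Also open, from the compounds shown here alone, is whether methoxy would give a true number on a core without the fluoro groups.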